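Furan to Fluoromethoxyphenyl at the Amine-Bound Chain Carbon

The compounds below may be only part of what the source reports. "The series", "measured", "known", "first", "only" and "open" are said of these compounds alone.

Compound 3 `COc1ccc(-c2ccc3c(NCCCNCc4ccco4)ccnc3c2)cc1` is the compound followed here. In a physicochemical assay for acid dissociation, compound 3 gives 9.47, level with compound 1 `COc1ccc(F)cc1CNCCCNc1ccnc2cc(Cc3ccc(C#N)cc3)ccc12`, which gives 9.47; compound 2 `COc1ccc(F)cc1CNCCCNc1ccnc2cc(Oc3cccc(N(C)C)c3)ccc12` gives 9.28, and the step of a number 0.19 log units lower from compound 1 to compound 2 (within the scatter) stays within the scatter. Compound 3 and compound 1 together hold the highest of the three numbers, with no difference between them at the digits shown.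

Compound 4 `COc1ccc(-c2ccc3c(NCCCNCc4cc(F)ccc4OC)ccnc3c2)cc1` differs from compound 3 by 5-fluoro-2-methoxyphenyl in place of furan-2-yl on a saturated chain carbon bound to an amine nitrogen. Going by the values given here, no measured step touches this position: the only measured step, a number 0.19 log units lower from compound 1 to compound 2 (within the scatter), alters a group on an aromatic carbon of the shared core, not the group on the chain carbon bound to the amine nitrogen. What the data do offer is that compound 1 and compound 2 already carry the 5-fluoro-2-methoxybenzyl group entering here, and their values sit level with that of compound 3 within the scatter. For compound 4 the expected step is a number 0.02 log units lower from compound 3 to compound 4 (within the scatter), none beyond the scatter. The estimate for compound 4 is 9.45, ranging from 9.1 to 9.8.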

Compound 4, acid dissociation constant: 9.47
Beside the measured number, compound 4's estimate is 0.02 log units below it; the measured number falls inside the stated range.
By their numbers in this assay, from the lowest: compounds 2, 1, 3 and 4 (each within the scatter of the next).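

In this assay, the change on a saturated chain carbon bound to an amine nitrogen now has a direct reading, no change at the digits printed from compound 3 to compound 4 (within the scatter), so the number does not separate furan-2-yl from 5-fluoro-2-methoxyphenyl at this position. With the 5-fluoro-2-methoxybenzyl group held fixed, the group on the aromatic carbon can be read too: no change at the digits printed from compound 1 to compound 4 (within the scatter), and a number 0.19 log units higher from compound 2 to compound 4 (within the scatter), which places 4-methoxyphenyl with the other two groups there, all within the scatter. Nothing further is available to account for this result.

Only these two groups can be compared on the chain carbon. On these data alone, whether a carboxylic acid, an amine or a longer chain in place of furan-2-yl would move the number beyond the scatter stays open.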